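This account rests on a few compounds, and the source may have more. Where it says the series, first, only, none or still open, it means among the compounds named here.

Going by the values given here, compound 2, `COc1ccc(/C=N/NC(=S)NC(C)(C)[C@H]2CC=C(C)CC2)cc1`, is the one member of this small set with a number in a functional assay on 786-0 cells (Homo sapiens) for inhibition, read by sulforhodamine B assay, with a stated time of 48 h (a higher number here means a weaker inhibitor of growth, a lower number a stronger inhibitor of growth), where compound 2 gives 8900 nM. Its two companions go no further than a limit. Compound 1, `CC1=CC[C@H](C(C)(C)N=C=S)CC1`, returns in this assay only the limit > 100000 nM, not a number. Compound 3, `CC1=CC[C@H](C(C)(C)NC(=S)N/N=C/c2cccc([N+](=O)[O-])c2)CC1`, likewise returns in this assay only the limit > 100000 nM. Among the compounds with values here, the single evidence about the measured compounds is therefore (the limit of > 100000 nM in this assay, at which 2 of the 3 values shown sit). Within the data shown here, compound 2 thus stands alone as the one measured value, with no step between measured compounds to lean on.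

The compound now under consideration is compound 4, `CC1=CC[C@H](C(C)(C)NC(=S)N/N=C/c2ccc[nH]2)CC1`. It departs from compound 2 by 1H-pyrrol-2-yl in place of 4-methoxyphenyl on a carbon with a double bond to nitrogen. The thiosemicarbazone part of compound 2 is kept, and only the aromatic group hanging from the carbon with a double bond to nitrogen is exchanged.

Among the measured compounds shown here, with no measured step available, the size of the change can only be guessed from the shape of the data. Two of three compounds sit at the limit, and only compound 2 gives a number, so a loss of growth inhibition is the more likely outcome, possibly back to the limit, though a value near that of compound 2 cannot be ruled out. On that basis the step from compound 2 to compound 4 in this assay is expected to be a 3.4-fold higher number from compound 2 to compound 4 (0.53 log units; beyond the scatter). Compound 4 is therefore estimated in this assay at 30000 nM, with a range from 8000 nM to 100000 nM.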

Compound 4, concentration for 50% growth inhibition: 20800 nM
Compound 4: the middle estimate sits 1.4-fold (0.16 log units) above what was measured; the measured number falls inside the stated range.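

Going by these compounds alone, the step gives the first measured reading at this position in this assay: replacing 4-methoxyphenyl with 1H-pyrrol-2-yl on a carbon with a double bond to nitrogen produces a 2.3-fold higher number from compound 2 to compound 4 (0.37 log units; beyond the scatter). The loss is real but limited, so a numerical growth-inhibition value is no longer confined to compound 2 and survives the exchange of a six-membered aromatic ring of carbon only for a five-membered aromatic ring with 1 hetero atom. Even so, a number cannot be taken for granted among the compounds carrying this thiosemicarbazone part, since compound 3 returns only a limit, and across the set the limit remains common: the limit of > 100000 nM in this assay, at which 2 of the 4 values shown sit.

This single exchange changes ring size, hetero atom and hydrogen-bond donor count together, so the compounds shown cannot say which of these differences goes with the higher number. They also leave open whether a plain phenyl, a furan-2-yl, a thiophen-2-yl or an N-methylpyrrol-2-yl group on the same carbon would give a number close to that of compound 2 or of compound 4, or only a limit.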